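Furan-2-yl to Pyridin-4-yl on a Hydroxyphenyl-Bearing Core

A few compounds are considered here, and "the series" means these few. Any claim that something is new, unique, unknown or untested is made for them only; others in the source may bear on it.

The study concerns inhibition of a human enzyme, followed in an assay on isolated protein for inhibition of DNA topoisomerase 1 (Homo sapiens), with a stated time of 30 min, tested at 20 uM; on this read-out higher numbers stand for a stronger effect at the one concentration tested and lower numbers for a weaker effect. Compound 1 `Oc1cccc(-c2cc(-c3ccccc3)cc(-c3ccco3)n2)c1` is the starting point; in this assay compound 1 gives 0%. Compound 2 `Oc1cccc(-c2cc(-c3ccccc3)cc(-c3ccncc3)n2)c1` keeps the rest of the molecule and, in this assay, compound 2 gives 25.4%. The structural change between them is pyridin-4-yl in place of furan-2-yl on an aromatic carbon and it produces a step of a number 25.4 percentage points higher from compound 1 to compound 2 (beyond the scatter).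

Compound 3 `Oc1ccc(-c2cc(-c3ccccc3)nc(-c3ccco3)c2)cc1` has the same atoms as compound 1 joined differently; how the two cores differ is not broken down here, and in this assay compound 3 is recorded as "not determined" (no result reported).

Compound 4 `Oc1ccc(-c2cc(-c3ccccc3)nc(-c3ccncc3)c2)cc1` has not yet been measured. It differs from compound 3 by pyridin-4-yl in place of furan-2-yl on an aromatic carbon, the same kind of change as that from compound 1 to compound 2; it occurs twice among the compounds shown. The surroundings are not identical: in compound 4 the entering group sits meta to a 4-hydroxyphenyl group, whereas in compound 2 it sits meta to a 3-hydroxyphenyl group.

With no number for compound 3, the expectation for compound 4 rests on the modest step of a number 25.4 percentage points higher from compound 1 to compound 2 (beyond the scatter) and on the low value of compound 1, 0%, taken as the likely level of compound 3. Compound 4 is therefore expected to reach about 20% in this assay, with a range estimated from 0% to 45%.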

Compound 4, a percentage reported as inhibition, at one concentration (the size of the read-out at that concentration, not a potency): 5.8%
Compound 4: the middle estimate sits 14.2 percentage points above what was measured; measured number inside the range.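

In this assay, among the compounds shown here, compound 3 has no number, so no step from compound 3 to compound 4 can be read, and compound 4 stands alone at 5.8% here. The compounds shown leave open whether pyridin-4-yl in place of furan-2-yl on the core of compound 3 would match the step of a number 25.4 percentage points higher from compound 1 to compound 2 (beyond the scatter) or not. No evidence is available that bears on this result.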